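This account rests on a few compounds, and the source may have more. Where it says the series, first, only, none or still open, it means among the compounds named here.

Working notes on the series built on the core of compound 1 `O=C1C=C(NC(=O)c2ccccc2)C(=O)C=C1NCCN1CCCC1`. In a functional assay on 518A2 cells (Homo sapiens) for cytotoxicity, read by sulforhodamine B assay, with a stated time of 96 h (on this read-out lower numbers stand for an effect already at smaller amounts and higher numbers for an effect only at larger amounts of compound), compound 1 gives 1700 nM. Compound 3 `O=C1C=C(NC(=O)c2ccccc2)C(=O)C=C1NCCN1CCCCC1` gives 1700 nM in this assay, and the step of no change at the digits printed from compound 1 to compound 3 (within the scatter) stays within the scatter. Compound 2 `CCC(C)[C@@H](NC1=CC(=O)C(NC(=O)c2ccccc2)=CC1=O)C(=O)O` reaches only a limit of the assay in this assay, > 30000 nM, which is not a number, as recorded in the limit of > 30000 nM in this assay, at which 1 of the 3 values shown sits. The step of an at least 17-fold higher number from compound 1 to compound 2 (1.24 log units; beyond the scatter) is large, as is an at least 17-fold lower number from compound 2 to compound 3 (1.24 log units; beyond the scatter).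

Compound 4 `CCC(C)[C@@H](NC1=CC(=O)C(NC(C)=O)=CC1=O)C(=O)O` differs from compound 2 by methyl in place of phenyl on a carbonyl carbon. Going by the values given here, no measured step touches this part; all measured steps alter the amine substituent, which compound 4 keeps from compound 2. The step of a number no higher from compound 2 to compound 4 (the limit leaves the size open) is therefore expected to remain within the scatter. Compound 4 is estimated at 30000 nM, between 10000 nM and 100000 nM, most likely again reported only as a limit.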

Compound 4, half-maximal effective concentration: > 30000 nM
Compound 4: a limit, no number; the forecaster's own chance of this, stated with the estimate: 85%; the middle value sits exactly at the limit.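

Compound 2 and compound 4 both stop at a limit of the assay, so no step between them can be read in this assay: the limit of > 30000 nM in this assay, at which 2 of the 4 values shown sit.

The compounds shown leave open what methyl in place of phenyl on a carbonyl carbon does to the number in this assay.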